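This account rests on a few compounds, and the source may have more. Where it says the series, first, only, none or still open, it means among the compounds named here.

Measured compounds and their values:
Compound 1, `COc1ccccc1N1C(=O)C(C)SC1c1cccc(C(=O)NCCCCc2ccccc2)c1`: 82%
Compound 2, `O=C(NCCCCc1ccccc1)c1cccc(C2OCC(=O)N2c2cccc(F)c2)c1`: 29%
Compound 3, `COc1c(F)cccc1N1C(=O)CSC1c1cccc(C(=O)NCCCCc2ccccc2)c1`: 9%

In a functional assay on HOS cells (Homo sapiens) for inhibition, read by CCK-8 assay, with a stated time of 72 h, tested at 1 uM (a higher number here means more inhibition at the concentration tested (going by the name of the read-out), a lower number less inhibition), compound 3 gives 9%, the lowest of the three numbers. Compound 2, its nearest neighbour, sits beyond the scatter above it, and compound 1 lies furthest away, also beyond the scatter. Within the data shown here, compound 1 and compound 3 differ in more than one place, so no single step between measured compounds is available, and the data give no step at all of the kind needed here.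

Compound 4, `COc1ccc(N2C(=O)CSC2c2cccc(C(=O)NCCCCc3ccccc3)c2)c(OC)c1`, has not been measured. It differs from compound 3 in one place: 2,4-dimethoxyphenyl in place of 3-fluoro-2-methoxyphenyl on an amide-type nitrogen in a ring. Among the measured compounds shown here, with no matching step on record, the expectation rests only on where compound 3 stands and on the high value of compound 1, which also carries a methoxy group on that nitrogen-borne phenyl ring. The step from compound 3 to compound 4 is expected to be upward, of a size beyond the scatter, a number 26 percentage points higher from compound 3 to compound 4 (beyond the scatter), though with wide uncertainty. Compound 4 is therefore estimated at 35%, within a range of 5% to 75%.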

Compound 4, a percentage reported as inhibition, at one concentration (the size of the read-out at that concentration, not a potency): 82%
Compound 4: the middle estimate sits 47 percentage points below what was measured; measured number above the stated range.
By their numbers in this assay, from the lowest: compound 3; then compound 2; then compounds 1 and 4 (each within the scatter of the next).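

In this assay, among these compounds, putting 2,4-dimethoxyphenyl in place of 3-fluoro-2-methoxyphenyl on the amide-type nitrogen in a ring gives a number 73 percentage points higher from compound 3 to compound 4 (beyond the scatter), the first step in this set between measured compounds that differ in only one place. It shows that this position, two ring bonds from the ring sulfur, can by itself take a compound from the lowest number in the set to the highest group. Nothing available accounts for the size of this step.

The compounds shown leave open whether the step follows from losing the fluorine, from gaining the second methoxy group, or from both together. Also open, from the compounds shown here alone, is how an amine or a carboxylic acid on this phenyl ring would read in this assay.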